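Compound 4: Pyrimidin-5-yl in Place of Pyridin-3-yl

This account rests on a few compounds, and the source may have more. Where it says the series, first, only, none or still open, it means among the compounds named here.

Compound 3 `CC(Sc1nc2c(cnn2C)c(=O)n1-c1ccccc1)c1cccnc1` gives 89 nM in an assay on isolated protein for inhibition of retinal dehydrogenase 2 (Homo sapiens); a lower number here means a stronger inhibitor, a higher number a weaker inhibitor. Among the three compounds measured it stands second highest: compound 1 `C[C@@H](Sc1nc2c(cnn2C)c(=O)n1-c1ccccc1)c1ccccc1` gives 40 nM, and compound 2 `CC(Sc1nc2c(cnn2C)c(=O)n1-c1ccccc1)c1cccc(F)c1` gives 110 nM. The step of a 2.2-fold higher number from compound 1 to compound 3 (0.35 log units; beyond the scatter) lies beyond the scatter, whereas a 1.2-fold lower number from compound 2 to compound 3 (0.09 log units; within the scatter) lies within it, so compound 2 and compound 3 cannot be ordered against each other on these numbers. The step of a 2.8-fold higher number from compound 1 to compound 2 (0.44 log units; beyond the scatter) shows the same modest loss on exchanging the 1-phenylethyl group.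

Compound 4 `CC(Sc1nc2c(cnn2C)c(=O)n1-c1ccccc1)c1cncnc1` carries the change (pyrimidin-5-yl in place of pyridin-3-yl on a saturated chain carbon bound to a saturated chain carbon and a sulfur). The two steps that bear on it, both single exchanges of the ring on the saturated chain carbon bound to a saturated chain carbon and a sulfur, were modest and went toward weaker inhibition, while the exchange between compound 2 and compound 3 made no difference beyond the scatter. A further modest step in the same direction, or none beyond the scatter, is therefore expected in this assay. The estimated step of a 1.7-fold higher number from compound 3 to compound 4 (0.23 log units; within the scatter) is expected to be small. Compound 4 is expected to give about 150 nM, in a range from 60 nM to 400 nM.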

Compound 4, half-maximal inhibitory concentration: 380 nM
The estimate for compound 4 lay 2.5-fold (0.40 log units) below the measured number, within the range that was stated.
By their numbers in this assay, from the lowest: compound 1; then compounds 3 and 2 (each within the scatter of the next); then compound 4.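

In this assay, the ring on the saturated chain carbon bound to a saturated chain carbon and a sulfur proves sensitive to a further ring nitrogen: a 4.3-fold higher number from compound 3 to compound 4 (0.63 log units; beyond the scatter) is the exchange of pyridin-3-yl for pyrimidin-5-yl, while compounds 2 and 3 could not be separated. With a 3.5-fold higher number from compound 2 to compound 4 (0.54 log units; beyond the scatter) and a 9.5-fold higher number from compound 1 to compound 4 (0.98 log units; beyond the scatter) beyond the scatter as well, compound 4 is the weakest of the four, and the number rises from compound 1 through compound 3 to compound 4 as ring nitrogens are added, although compound 2, with a fluorine and no ring nitrogen, stands within the scatter of compound 3. Nothing available here explains this loss.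

The compounds shown leave open whether pyridin-4-yl or pyridin-2-yl would behave like pyridin-3-yl. They also leave open whether an amine on the pyrimidin-5-yl ring would change the result.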